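This account rests on a few compounds, and the source may have more. Where it says the series, first, only, none or still open, it means among the compounds named here.

Compound 1 `COc1nc2c(c(=O)n(C)c(=O)n2C)n1CC(=O)Nc1cccc(Cl)c1`: in an assay on isolated protein for inhibition of high affinity 3',5'-cyclic-AMP phosphodiesterase 7A (Homo sapiens), read by cAMP accumulation, with a stated time of 10 min (on this read-out higher numbers stand for weaker inhibition and lower numbers for stronger inhibition), compound 1 gives only the assay limit, > 200000 nM.
Compound 2 `COc1nc2c(c(=O)n(C)c(=O)n2C)n1CCCC(=O)Nc1ccc(Cl)cc1`: in this assay compound 2 gives only the assay limit, > 200000 nM.
Compound 3 `CCOc1nc2c(c(=O)n(C)c(=O)n2C)n1CC(=O)Nc1cccc(Cl)c1`: in this assay compound 3 gives only the assay limit, > 200000 nM.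

Compound 3 stands at the limit, and so does every other value shown: the limit of > 200000 nM in this assay, at which 3 of the 3 values shown sit. Among the compounds with values here, the only measured step, a step that the two limits leave unreadable from compound 1 to compound 3, cannot be read because both of its ends sit at the limit of > 200000 nM in this assay, at which 3 of the 3 values shown sit. Within the data shown here, no measured step touches the amide nitrogen, so nothing here supports a direction.

Compound 4 `CCOc1nc2c(c(=O)n(C)c(=O)n2C)n1CC(=O)NCc1ccccc1Cl` differs from compound 3 by 2-chlorobenzyl in place of 3-chlorophenyl on an amide-type nitrogen. With all three neighbours at the limit, compound 4 is expected to remain near it, estimated at 300000 nM (range 50000 nM to 2000000 nM). The expected step is a step that the limit leaves unreadable from compound 3 to compound 4, and a reported limit rather than a number is the likelier outcome.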

Compound 4, half-maximal inhibitory concentration: > 200000 nM
Compound 4 gave a limit, no number (the forecaster's own chance of this, stated with the estimate: 80%); the middle value is on the limit's open side.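

No new step can be read: compound 3 and compound 4 both give only a limit, not a number: the limit of > 200000 nM in this assay, at which 4 of the 4 values shown sit.

The compounds shown leave open which change to the shared core or its amide side chain, if any, would give a number in this assay.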